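This account rests on a few compounds, and the source may have more. Where it says the series, first, only, none or still open, it means among the compounds named here.

Working notes on the series: in an ADME assay on microsomes from liver (Homo sapiens) for metabolic stability, read by LC-MS, with a stated time of 10 min (a higher number here means that more of the compound is left, a lower number that less of the compound is left), compound 1 `CN(C[C@H]1Cc2c(cccc2N2CCN(C3COC3)CC2)CN1)[C@H]1CCCc2cccnc21` gives 83.1%, the second highest of three measured numbers. Compound 2 `CN(C[C@@H]1Cc2c(cccc2N2CCNCC2)CN1)[C@H]1CCCc2cccnc21` stands higher at 94.2% and compound 3 `FC1(F)CCC(CN(C[C@H]2Cc3c(cccc3N3CCNCC3)CN2)[C@H]2CCCc3cccnc32)CC1` lower at 68.6%, both gaps beyond the scatter. Compound 4 `C[C@@H]1CN(c2cccc3c2C[C@H](CN(C)[C@H]2CCCc4cccnc42)NC3)C[C@H](C)N1C` keeps the core of compound 1 and differs by 3,4,5-trimethylpiperazin-1-yl in place of 4-(oxetan-3-yl)piperazin-1-yl on an aromatic carbon. Among the measured compounds shown here, no measured pair differs in one place only, so the closest guide is compound 1 at 83.1%. In this assay, a small fall is expected, a number 5.1 percentage points lower from compound 1 to compound 4 (within the scatter), not beyond the scatter. For compound 4 the estimated value is 78%, with an expected range of 62% to 90%.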

Compound 4, percent of the compound remaining: 24.6%
Compound 4: middle estimate off by 53.4 percentage points, on the high side; the measured number lies below the stated range.
By their numbers in this assay, from the lowest: compound 4; then compound 3; then compound 1; then compound 2.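

In this assay, among the compounds shown here, 3,4,5-trimethylpiperazin-1-yl in place of 4-(oxetan-3-yl)piperazin-1-yl on an aromatic carbon gives a number 58.5 percentage points lower from compound 1 to compound 4 (beyond the scatter) and forms the first one-place step. For the compounds shown here, the group at this aromatic carbon can therefore move the number far on its own, which the earlier compounds could not show. Nothing at hand accounts for the size of this step.

As far as these compounds go, whether the loss of the oxetane ring or the entry of the methyl groups carries the step stays open. So does what morpholin-4-yl or 4-methylpiperazin-1-yl would give at this carbon.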